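Swapping a Methoxyphenyl for a Pyrazinyl on a Shared Core

The source may report more compounds than this note shows. Statements on the series, on what has been measured and on what is new or still open speak of the compounds shown alone.

Compound 2 `COc1cccc(-c2nc(N)c3cc(Cc4ccccc4)sc3n2)c1` gives 266 nM in a functional assay on CHO-K1 cells for antagonist activity at adenosine receptor A1 (Homo sapiens), read by a beta-galactosidase reporter and cAMP accumulation, with stated times of 15 min and 6 h; a lower number here means a stronger inhibitor, a higher number a weaker inhibitor. Compound 1 `Cc1nc(-c2nc(N)c3cc(Cc4ccccc4)sc3n2)cs1`, which carries a 2-methyl-1,3-thiazol-4-yl group instead of the 3-methoxyphenyl, gives 263 nM in this assay, and the step of a 1.0-fold higher number from compound 1 to compound 2 (0.00 log units; within the scatter) lies within the scatter. Compound 3 `Nc1nc(-c2cnccn2)nc2sc(Cc3ccccc3)cc12` differs from compound 2 by pyrazin-2-yl in place of 3-methoxyphenyl on an aromatic carbon. Within the data shown here, the single known step, a 1.0-fold higher number from compound 1 to compound 2 (0.00 log units; within the scatter), shows that trading a heteroaromatic ring for the methoxyphenyl left the number unchanged, so no step beyond the scatter is expected here either. Compound 3 is therefore estimated at 250 nM, within 80 nM to 800 nM, a step of a 1.1-fold lower number from compound 2 to compound 3 (0.03 log units; within the scatter).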

Compound 3, inhibition constant: 91 nM
Estimate against measurement, compound 3: 2.7-fold (0.44 log units) above, and the stated range covers the measured number.
By their numbers in this assay, from the lowest: compound 3; then compounds 1 and 2 (each within the scatter of the next).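

In this assay, putting pyrazin-2-yl on this aromatic carbon gives a 2.9-fold lower number from compound 2 to compound 3 (0.47 log units; beyond the scatter) and also a 2.9-fold lower number from compound 1 to compound 3 (0.46 log units; beyond the scatter) when it replaces 2-methyl-1,3-thiazol-4-yl. The number at this position can therefore move with the ring it carries, something compound 1 and compound 2, level within the scatter, gave no sign of. Nothing available explains this step. Still open, from the compounds shown here alone, is whether the lower number depends on having two ring nitrogens, and a pyridin-2-yl ring would speak to that. Going by these compounds, how a non-aromatic group, such as a simple amine on this carbon, would read also remains open.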